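Swapping the urea substituent on a shared core

This account rests on a few compounds, and the source may have more. Where it says the series, first, only, none or still open, it means among the compounds named here.

Compound 1 `C[C@@H]1CN(Cc2ccccc2)c2nc(C(F)(F)F)ccc2[C@H](C)N1C(=O)NCc1ccccc1`: 57 nM
Compound 2 `C[C@@H]1CN(Cc2ccccc2)c2cncc(F)c2[C@H](C)N1C(=O)Nc1cccnc1`: 107 nM
Compound 3 `C[C@@H]1CN(Cc2ccccc2)c2ccncc2[C@H](C)N1C(=O)NCc1ccccc1`: 6280 nM

Of the compounds shown here, three built on closely related cores have been tested in an assay on HEK293 cells for inhibition of Voltage-dependent T-type calcium channel subunit alpha-1G (Homo sapiens), read by FLIPR and calcium flux, with a stated time of 3 min; on this read-out higher numbers stand for weaker inhibition and lower numbers for stronger inhibition. Compound 2 stands second highest of the three numbers. Its nearest neighbour is compound 1, whose number lies within the scatter of repeated measurements, so the two cannot be told apart. Compound 3 lies far higher, a gap well beyond the scatter, so compound 3 is clearly the weaker inhibitor of that pair.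

Compound 4 `C[C@@H]1CN(Cc2ccccc2)c2cncc(F)c2[C@H](C)N1C(=O)NCc1ccccc1` has not yet been measured. It keeps the core of compound 2 and differs only at the urea: benzyl in place of pyridin-3-yl on an amide-type nitrogen. Among the measured compounds shown here, no pair of measured compounds shows this exact change, so its effect is not known from the data. For the measured compounds named here, what can be said is that a benzyl urea on a different core gives compound 1 its value of 57 nM, while on yet another core compound 3 gives 6280 nM; the core, not the urea substituent, seems to drive that spread, though only two examples support this.

For compound 4 in this assay the step from compound 2 is expected to be small, a 1.1-fold higher number from compound 2 to compound 4 (0.05 log units; within the scatter), within the scatter. The estimated value for compound 4 is 120 nM, with a range from 30 nM to 500 nM.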

Compound 4, half-maximal inhibitory concentration in the Voltage-dependent T-type calcium channel subunit alpha-1G assay: 140 nM
Beside the measured number, compound 4's estimate is 1.2-fold (0.07 log units) below it, and the stated range covers the measured number.
By their numbers in the Voltage-dependent T-type calcium channel subunit alpha-1G assay, from the lowest: compounds 1, 2 and 4 (each within the scatter of the next, the first and the last beyond it); then compound 3.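

In the Voltage-dependent T-type calcium channel subunit alpha-1G assay compound 2 gives 107 nM and compound 4 gives 140 nM. Among the compounds shown here, in the Voltage-dependent T-type calcium channel subunit alpha-1G assay, benzyl in place of pyridin-3-yl on the amide-type nitrogen gives the first direct reading at this position, a 1.3-fold higher number from compound 2 to compound 4 (0.12 log units; within the scatter), so on this core the two groups cannot be told apart, even though pyridin-3-yl has 1 hydrogen-bond acceptor and benzyl has 0 hydrogen-bond acceptors. In a physicochemical assay for lipophilicity, at pH 7.4 (on this read-out higher numbers stand for higher lipophilicity and lower numbers for lower lipophilicity), compound 2 carries 3.3 and compound 4 carries "not determined" (no result reported), so the same change cannot be read on that scale. No measured evidence here accounts for how little the swap alters inhibition.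

Whether the same swap is as quiet on the core of compound 1 or on the core of compound 3 remains open, since pyridin-3-yl is shown on only one core. Also open, from the compounds shown here alone, is how far this position accepts other groups on the amide-type nitrogen, such as a longer chain like phenylethyl, or a benzyl ring bearing a carboxylic acid or an amine.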